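Nitrophenyl amide positional variants in the azo-indole series

This account rests on a few compounds, and the source may have more. Where it says the series, first, only, none or still open, it means among the compounds named here.

Measured compounds:
Compound 1, `O=C(Nc1ccccc1[N+](=O)[O-])c1ccc(/N=N\c2c[nH]c3ccccc23)cc1`: 101000 nM
Compound 2, `O=C(Nc1ccc([N+](=O)[O-])cc1)c1ccc(/N=N\c2c[nH]c3ccccc23)cc1`: 54500 nM

Going by the values given here, compound 2 gives the lowest number of the two measured in a functional assay on MCF7 cells (Homo sapiens) for inhibition, read by MTT assay, with a stated time of 72 h (on this read-out higher numbers stand for weaker inhibition and lower numbers for stronger inhibition), but its only neighbour is compound 1, and the step of a 1.9-fold lower number from compound 1 to compound 2 (0.27 log units; within the scatter) lies within the scatter, so no ordering of the two compounds is claimed.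

Compound 3, `O=C(Nc1cccc([N+](=O)[O-])c1)c1ccc(/N=N\c2c[nH]c3ccccc23)cc1`, is not yet measured. It differs from compound 2 by 3-nitrophenyl in place of 4-nitrophenyl on an amide-type nitrogen. Among the compounds with values here, the only step that bears on this change is the move of the nitro group from the 2-nitrophenyl to the 4-nitrophenyl, a 1.9-fold lower number from compound 1 to compound 2 (0.27 log units; within the scatter), which stayed within the scatter. A third placement of the same group on the same amide-type nitrogen is therefore expected to move the number by no more than the scatter in either direction, a 1.2-fold higher number from compound 2 to compound 3 (0.08 log units; within the scatter). Compound 3 is thus estimated at 65000 nM, within a range from 25000 nM to 160000 nM, given the weak inhibition of both measured compounds.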

Compound 3, half-maximal inhibitory concentration: 51900 nM
Compound 3: the middle estimate sits 1.3-fold (0.10 log units) above what was measured; measured number inside the range.
By their numbers in this assay, from the lowest: compounds 3, 2 and 1 (each within the scatter of the next).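

With 3-nitrophenyl on the amide-type nitrogen, three placements of the nitro group can now be compared, and this assay gives a 1.1-fold lower number from compound 2 to compound 3 (0.02 log units; within the scatter) and a 1.9-fold lower number from compound 1 to compound 3 (0.29 log units; within the scatter). The step between the 4-nitrophenyl and 3-nitrophenyl compounds adds a second within-scatter comparison to the earlier one, so across compound 1, compound 2 and compound 3 no placement of the nitro group can be ranked on this read-out. No measured information is available to explain these numbers.

Still open, from the compounds shown here alone, is whether a different group on this phenyl ring, such as an amine or a carboxylic acid, would move the number beyond the scatter. Also open, going by these compounds, is whether replacing the nitrophenyl on the amide-type nitrogen with a longer alkyl chain would do so.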